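Amide substituent swap at the weak end of the series

The compounds below may be only part of what the source reports. "The series", "measured", "known", "first", "only" and "open" are said of these compounds alone.

In an in vitro assay on BTI-TN-5B1-4 cells for inhibition of Amine oxidase [flavin-containing] B (Homo sapiens), read by fluorescence (on this read-out higher numbers stand for weaker inhibition and lower numbers for stronger inhibition), compound 1 `O=C(NC1CCCCC1)c1cc2ccccc2oc1=O` gives 500 nM, compound 2 `Cc1cccc(Cl)c1NC(=O)c1cc2ccccc2oc1=O` gives 19100 nM, and compound 3 `O=C(NC1CCCCC1)c1cc2ccc(OCc3ccccc3)cc2oc1=O` gives 64500 nM. Compound 3 stands highest of the three numbers; compound 2 lies nearest to it and compound 1 furthest, the gap in that direction being a 130-fold higher number from compound 1 to compound 3 (2.11 log units; beyond the scatter) for the benzyloxy in place of hydrogen on an aromatic carbon.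

Compound 4 `O=C(NCc1ccccc1)c1cc2ccc(OCc3ccccc3)cc2oc1=O` differs from compound 3 in one place: benzyl in place of cyclohexyl on an amide-type nitrogen. Within the data shown here, no measured step in this assay addresses that change. Among the measured compounds shown here, compound 1 and compound 2 carry different amide substituents; compound 1 shows 500 nM while compound 2 shows 19100 nM, but they form no single-place pair with compound 3 or compound 4, so they give no direct guide. With nothing to anchor the step, the working expectation is a step of a 1.1-fold lower number from compound 3 to compound 4 (0.03 log units; within the scatter), not beyond the scatter. Compound 4 is therefore estimated at 60000 nM in this assay, within a range of 20000 nM to 180000 nM.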

Compound 4, half-maximal inhibitory concentration: 990 nM
For compound 4 the middle estimate is 61-fold (1.78 log units) above the measured one; measured number below the stated range.
By their numbers in this assay, from the lowest: compounds 1 and 4 (each within the scatter of the next); then compound 2; then compound 3.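

At this amide-type nitrogen the substituent carries a large effect in this assay when benzyloxy is present: benzyl in place of cyclohexyl gives a 65-fold lower number from compound 3 to compound 4 (1.81 log units; beyond the scatter) as one step. The earlier step for benzyloxy, a 130-fold higher number from compound 1 to compound 3 (2.11 log units; beyond the scatter) with cyclohexyl on the nitrogen, therefore does not place every benzyloxy compound at the weak end of the series. Nothing measured here on either group bears on why the change has this size.

The step swaps a non-aromatic ring for an aromatic one and also adds a carbon, and cyclohexylmethyl on the same nitrogen would separate those two changes. From the compounds shown here alone, whether benzyl gives a step of this size without benzyloxy, and how a longer chain such as 2-phenylethyl would read at this nitrogen, stays open.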